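Dropping the Nitro Group for a Nitrile

A few compounds are considered here, and "the series" means these few. Any claim that something is new, unique, unknown or untested is made for them only; others in the source may bear on it.

In a functional assay on A-375 cells (Homo sapiens) for antiproliferative activity, read by MTT assay, with a stated time of 24 h (on this read-out lower numbers stand for stronger inhibition and higher numbers for weaker inhibition), compound 1 `COc1cc(OC)c(-c2coc3cc(OCc4ccc(F)cc4)ccc3c2=O)cc1OC` gives 1720 nM as its value. Compound 2 `COc1cc(OC)c(-c2coc3cc(OCc4ccc([N+](=O)[O-])cc4)ccc3c2=O)cc1OC` reads > 10000 nM and this is a limit of the assay, not a number. Among the measured compounds shown here, compound 2 therefore stands at the limit of > 10000 nM in this assay, at which 1 of the 2 values shown sits, on the numbers so far. Compound 3 `COc1cc(OC)c(-c2coc3cc(OCc4ccccc4C#N)ccc3c2=O)cc1OC` has 2-cyanophenyl in place of 4-nitrophenyl on a saturated chain carbon bound to an oxygen on an aromatic ring and so loses the nitro group. For the measured compounds named here, the only measured guide is an at least 5.8-fold higher number from compound 1 to compound 2 (0.76 log units; beyond the scatter) with nitro in place of fluoro on an aromatic carbon, so a move to lower numbers is expected in this assay for this change. The expected change is an at least 2.5-fold lower number from compound 2 to compound 3 (0.39 log units; beyond the scatter) in size. Compound 3 is estimated at 4000 nM within a range of 1200 nM to 10000 nM overall.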

Compound 3, half-maximal inhibitory concentration: 990 nM
For compound 3 the middle estimate is 4.0-fold (0.61 log units) above the measured one, and the stated range ends above it.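

In this assay, 2-cyanophenyl on this saturated chain carbon gives an at least 10-fold lower number from compound 2 to compound 3 (1.00 log units; beyond the scatter), so a substituted ring here need not lose activity the way 4-nitrophenyl does. That step is only a bound, and compound 2 reads as a limit of the assay, not a number: the limit of > 10000 nM in this assay, at which 1 of the 3 values shown sits. Set against 4-fluorophenyl, 2-cyanophenyl gives a 1.7-fold lower number from compound 1 to compound 3 (0.24 log units; within the scatter), so these two values cannot be ordered.

The change swaps both the group and its place on the ring, and the compounds shown do not separate these two effects. From the compounds shown here alone, how an amine or a carboxylic acid on this ring would read also stays open.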